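Replacing 4-methylpiperazin-1-yl on compound 3: working notes

The compounds below may be only part of what the source reports. "The series", "measured", "known", "first", "only" and "open" are said of these compounds alone.

Values in an in vitro ADME assay on microsomes from liver (Rattus norvegicus) for metabolic stability; on this read-out lower numbers stand for slow clearance and higher numbers for fast clearance:
- compound 1 `Cc1cc(Cn2c(=O)[nH]c3c(N)nc(C(F)(F)F)cc32)no1`: < 9 mL.min-1.g-1 (a limit)
- compound 2 `Cc1nc(Cn2c(=O)[nH]c3c(N)nc(C(F)(F)F)cc32)cs1`: < 10 mL.min-1.g-1 (a limit)
- compound 3 `CN1CCN(c2ccc(Cn3c(=O)[nH]c4c(N)nc(C(F)(F)F)cc43)cn2)CC1`: 46 mL.min-1.g-1

Going by the values given here, compound 3 stands at 46 mL.min-1.g-1, the only actual number here. The other two values are limits. Compound 4 `Nc1nc(C(F)(F)F)cc2c1[nH]c(=O)n2Cc1ccc(NCC2CC2)nc1` carries (cyclopropylmethyl)amino in place of 4-methylpiperazin-1-yl on an aromatic carbon. Among the compounds with values here, the one measured step, a step that the two limits leave unreadable from compound 1 to compound 2, has no readable size and concerns a different exchange, so it does not size this change. Compound 2 remains a limit at < 10 mL.min-1.g-1, which tilts the expectation slightly downward. The step expected in this assay is estimated as a 1.5-fold lower number from compound 3 to compound 4 (0.19 log units; within the scatter), leaning downward but not beyond the scatter. For compound 4 the expected value is 30 mL.min-1.g-1, with an estimated range of 10 mL.min-1.g-1 to 80 mL.min-1.g-1.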

Compound 4, intrinsic clearance in microsomes: 85 mL.min-1.g-1
Compound 4: the middle estimate sits 2.8-fold (0.45 log units) below what was measured; measured number outside the range, above it.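

In this assay, going by these compounds alone, (cyclopropylmethyl)amino in place of 4-methylpiperazin-1-yl on an aromatic carbon gives a 1.8-fold higher number from compound 3 to compound 4 (0.27 log units; within the scatter), the first readable step at this place next to the ring nitrogen. Losing the six-membered ring and bringing in a hydrogen-bond donor therefore moves the read-out no further than the scatter in this one pair. Nothing at hand accounts for the step.

The step between compound 1 and compound 2 cannot be read, as both values are limits. Going by these compounds, whether a morpholin-4-yl group or a carboxylic acid at this place would move the number beyond the scatter stays open.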